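The compounds below may be only part of what the source reports. "The series", "measured", "known", "first", "only" and "open" are said of these compounds alone.

Three compounds measured in an assay on HEK293 cells for positive allosteric modulation of metabotropic glutamate receptor 5 (Homo sapiens), read by FLIPR (on this read-out lower numbers stand for an effect already at smaller amounts and higher numbers for an effect only at larger amounts of compound), share a common core and differ only in the group attached to the amide carbonyl. Compound 1 `O=C(C1CCCCC1)N1CC(c2nc(-c3cccc(F)c3)no2)C1` gives 1000 nM in this assay. Compound 2 `O=C(N1CCC(F)CC1)N1CC(c2nc(-c3cccc(Cl)c3)no2)C1` gives 990 nM in this assay. Compound 3 `Cc1cccc(-c2noc(C3CN(C(=O)C4CCC(C(F)(F)F)CC4)C3)n2)c1` gives 1000 nM in this assay. Compound 2 has the lowest of the three numbers, but its gap to compound 1 and its gap to compound 3 both lie within the scatter of repeated measurements, so nothing separates the three on these values alone. Within the data shown here, no pair among them differs in only one place, so no single change can be tied to any shift in this assay.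

Compound 4 `O=C(c1ccccc1F)N1CC(c2nc(-c3cccc(Cl)c3)no2)C1` has not yet been measured. It differs from compound 2 in one place: 2-fluorophenyl in place of 4-fluoropiperidin-1-yl on a carbonyl carbon. A saturated ring attached through its nitrogen makes way for a flat aromatic ring attached through carbon, with the fluorine kept.

Because compound 1, compound 2 and compound 3 all gave values within the scatter of one another with quite different carbonyl substituents, compound 4 is expected to land near the same level, and the step of a 1.2-fold lower number from compound 2 to compound 4 (0.09 log units; within the scatter) is estimated to fall within the scatter or only slightly beyond it. Compound 4 is expected to give 800 nM, with a range from 250 nM to 2500 nM.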

Compound 4, half-maximal effective concentration: > 10000 nM
Compound 4: no number, only a limit; the forecaster's own chance of this, stated with the estimate: 10%; at least 12-fold (1.09 log units) between middle value and limit.
By their numbers in this assay, from the lowest: compounds 2, 1 and 3 (each within the scatter of the next). At a limit, above all of these: compound 4.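

Among these compounds, this is the first single change that can be tied to a shift: putting 2-fluorophenyl in place of 4-fluoropiperidin-1-yl on a carbonyl carbon gives an at least 10-fold higher number from compound 2 to compound 4 (1.00 log units; beyond the scatter), so the group at this position can decide the result in this assay. The change is sharper than a simple count of atoms suggests, as both groups hold 7 heavy atoms, one six-membered ring and one fluorine, with 0 hydrogen-bond donors, 0 hydrogen-bond acceptors and no net charge, and they differ in that one ring is non-aromatic with a nitrogen and the other is aromatic and of carbon only. Compound 4 gives > 10000 nM, which is a limit of the assay and not a number, so the true size of the step stays unknown: the limit of > 10000 nM in this assay, at which 1 of the 4 values shown sits.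

The compounds shown leave open whether the aromatic ring, the loss of the ring nitrogen or the place of the fluorine accounts for this step. A 4-fluorocyclohexyl group, a plain piperidin-1-yl or an unsubstituted phenyl on the same carbonyl carbon would help to tell these apart.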